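A dichlorophenyl chalcone weighed against its methoxyphenyl parent

This account rests on a few compounds, and the source may have more. Where it says the series, first, only, none or still open, it means among the compounds named here.

Three compounds carry results in a functional assay on DU-145 cells (Homo sapiens) for antiproliferative activity, read by MTT assay, with a stated time of 72 h; on this read-out lower numbers stand for stronger inhibition and higher numbers for weaker inhibition. Compound 1 `COc1ccccc1/C=C/C(=O)c1ccc(OCC(=O)N[C@H]2CCOC2=O)cc1` gives 10100 nM, the lower of the two numbers reported. Compound 3 `O=C1OCC[C@@H]1NC(=S)SCCOc1ccccc1` gives 63800 nM, a higher number. Compound 2 `O=C(CNc1ccccc1Cl)N[C@H]1CCOC1=O` is recorded only as a limit of the assay, > 64000 nM. That limit is noted as the limit of > 64000 nM in this assay, at which 1 of the 3 values shown sits, and nothing more is said of it. Among the compounds with values here, no two of the measured compounds differ in a single place, so no measured step can be drawn among them.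

Compound 4 `O=C(COc1ccc(C(=O)/C=C/c2ccc(Cl)cc2Cl)cc1)N[C@H]1CCOC1=O` has not yet been measured. It differs from compound 1 by 2,4-dichlorophenyl in place of 2-methoxyphenyl on a double-bonded chain carbon bound to a double-bonded chain carbon. Within the data shown here, since no measured step is available, the size of the change from compound 1 to compound 4 in this assay rests on expectation alone. The shared core of compound 1 stays intact, and the exchange is confined to one ring. A modest move toward stronger inhibition is expected, close to the edge of the usual scatter rather than clearly beyond it. Compound 4 is therefore expected to give about 5000 nM, with a range from 1500 nM to 20000 nM. The step of a 2.0-fold lower number from compound 1 to compound 4 (0.31 log units; beyond the scatter) is what this estimate means.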

Compound 4, half-maximal inhibitory concentration: 8610 nM
Compound 4: middle estimate off by 1.7-fold (0.24 log units), on the low side; the measured number falls inside the stated range.
By their numbers in this assay, from the lowest: compounds 4 and 1 (each within the scatter of the next); then compound 3. At a limit, above all of these: compound 2.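

In this assay, the exchange of 2-methoxyphenyl for 2,4-dichlorophenyl on a double-bonded chain carbon bound to a double-bonded chain carbon provides the only one-place comparison among these compounds, and the result is a 1.2-fold lower number from compound 1 to compound 4 (0.07 log units; within the scatter). The earlier compounds shown here could say nothing about this position, whereas this pair shows that it accepts two quite different substituted phenyl groups with the shared core unchanged, and that the hydrogen-bond acceptor counted in 2-methoxyphenyl, which has no counterpart in 2,4-dichlorophenyl, can go without the number moving beyond the scatter. Nothing measured here offers an explanation for why the two compounds read alike.

This single exchange does not show how far that tolerance extends, since compound 2 and compound 3 differ from this pair in more than one place and so add nothing about this position. From the compounds shown here alone, whether an amine or a carboxylic acid on this phenyl ring, or a longer chain in its place, would shift the number beyond the scatter remains open.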